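This account rests on a few compounds, and the source may have more. Where it says the series, first, only, none or still open, it means among the compounds named here.

Among the measured compounds shown here, compound 2 `COc1c(/C=C2/C(=O)Nc3ccc(Cl)cc32)c2ccccc2n1-c1ccccc1` is the compound with the higher of the two numbers so far: in a functional assay on cells (Cancer cell lines, Homo sapiens) for cytotoxicity, with a stated time of 48 h (a lower number here means a stronger inhibitor of growth, a higher number a weaker inhibitor of growth), compound 2 gives 9330 nM, whereas compound 1 `COc1c(/C=C2/C(=O)Nc3ccccc32)c2ccccc2n1-c1ccccc1` gives 1120 nM. For the measured compounds named here, the step from compound 1 to compound 2 an 8.3-fold higher number from compound 1 to compound 2 (0.92 log units; beyond the scatter) is the only measured change at that position, and it involved chloro in place of hydrogen on an aromatic carbon. Compound 3 `COc1ccc2c(c1)/C(=C\c1c(OC)n(-c3ccccc3)c3ccccc13)C(=O)N2` differs from compound 2 by methoxy in place of chloro on an aromatic carbon. Going by the values given here, no measured step shows methoxy at this position, so the direction of the change cannot be read from a precedent; the single relevant step, from compound 1 to compound 2, only shows that substitution there can move the number by a modest amount. Compound 3 is therefore expected to stay in the range between the two measured numbers, with the estimated step of a 2.1-fold lower number from compound 2 to compound 3 (0.32 log units; beyond the scatter), giving an estimate of 4500 nM with a range from 1200 nM to 18000 nM.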

Compound 3, concentration for 50% growth inhibition: 2630 nM
Beside the measured number, compound 3's estimate is 1.7-fold (0.23 log units) above it; the range from low to high includes it.
By their numbers in this assay, from the lowest: compound 1; then compound 3; then compound 2.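

The position now has a second substituent to compare with chloro, and in this assay the two are not equivalent: methoxy in place of chloro gives a 3.5-fold lower number from compound 2 to compound 3 (0.55 log units; beyond the scatter) and so shows that the outcome at this aromatic carbon depends on which group sits there. Methoxy does not restore the parent level either, since the comparison with hydrogen shows a 2.3-fold higher number from compound 1 to compound 3 (0.37 log units; beyond the scatter) and thus leaves hydrogen with the lowest number of the three, with both substituents raising it by unequal amounts and no compound shown going against this. No measurement is available that accounts for the difference between the two groups.

The compounds shown leave open whether any group on this carbon can match or improve on hydrogen. An amine, a carboxylic acid or a longer chain such as ethoxy could fall on either side of it.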